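The source may report more compounds than this note shows. Statements on the series, on what has been measured and on what is new or still open speak of the compounds shown alone.

compound 1 `CCN(CC)C(=O)CN(c1ccc(C)cc1)S(=O)(=O)c1cccc(C)c1` 60 nM
compound 2 `CCN(CC)C(=O)CN(c1ccc(C)cc1)S(=O)(=O)c1ccccc1C` 58 nM

In a functional assay on CHO cells for inhibition of Orexin receptor type 2 (Homo sapiens), read by FLIPR and calcium flux (a higher number here means a weaker inhibitor, a lower number a stronger inhibitor), compound 2 gives 58 nM, and compound 1 sits alongside it within the scatter: a 1.0-fold lower number from compound 1 to compound 2 (0.01 log units; within the scatter). Compound 3 `CCN(CC)C(=O)CN(c1ccc(C)cc1)S(=O)(=O)c1ccccc1F` is not yet measured. Its change from compound 2 is fluoro in place of methyl on an aromatic carbon. Within the data shown here, no measured step exchanges one group for another of a different kind; the only step moves a methyl around the ring and stays within the scatter, so it bears only loosely on this change. Compound 3 is therefore expected to remain close to compound 2, an estimated 1.4-fold higher number from compound 2 to compound 3 (0.14 log units; within the scatter). The estimate for compound 3 is 80 nM, expected between 30 nM and 220 nM.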

Compound 3, half-maximal inhibitory concentration: 3370 nM
Compound 3: middle estimate off by 42-fold (1.62 log units), on the low side; the whole stated range lies below it.
By their numbers in this assay, from the lowest: compounds 2 and 1 (each within the scatter of the next); then compound 3.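

At this position, ortho to a large group, the identity of the substituent matters strongly in this assay: fluoro in place of methyl gives a 58-fold higher number from compound 2 to compound 3 (1.76 log units; beyond the scatter), although the heavy-atom count stays the same. The comparison with the 3-methylphenyl analogue agrees, with a 56-fold higher number from compound 1 to compound 3 (1.75 log units; beyond the scatter), so both methyl placements stand well apart from 2-fluorophenyl. Nothing measured here explains this loss.

From the compounds shown here alone, whether chloro, methoxy or ethyl on this carbon behaves like methyl or like fluoro remains open. Also open, going by these compounds, is whether fluoro on other ring carbons carries the same penalty.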